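A few compounds are considered here, and "the series" means these few. Any claim that something is new, unique, unknown or untested is made for them only; others in the source may bear on it.

Measured compounds:
compound 1 `O=C1NC(=O)/C(=C/C(c2ccc(-c3ccc4cccc(F)c4c3)[nH]c2=O)C2CCCCC2)O1` — 4 nM
compound 2 `CC(C)[C@H](C[C@H]1OC(=O)NC1=O)c1ccc(-c2ccc3cccc(F)c3c2)[nH]c1=O` — 6 nM
compound 3 `CCC(/C=C1\OC(=O)NC1=O)(CC)c1ccc(-c2ccc3c(c2)OC(C)(C)CC3)[nH]c1=O` — 2600 nM

In an assay on membranes from Chem-1 cells for displacement of a labelled ligand from prostaglandin E2 receptor EP3 subtype (Homo sapiens), read by scintillation counting, with a stated time of 2 h (a lower number here means a stronger inhibitor, a higher number a weaker inhibitor), compound 1 gives the lowest number of the three. Compound 2, with its own value of 6 nM, sits within the scatter of compound 1, so no order between these two can be claimed. Compound 3, at 2600 nM, lies far beyond the scatter from compound 1; it differs from compound 1 in more than one place, as does compound 2, so neither pair isolates a single structural change.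

Compound 4 `O=C1NC(=O)/C(=C/C(Cc2ccccc2)c2ccc(-c3ccc4cccc(F)c4c3)[nH]c2=O)O1` has not yet been measured in this assay. It differs from compound 1 by benzyl in place of cyclohexyl on a saturated chain carbon bound to an aromatic carbon and a double-bonded chain carbon. Among the measured compounds shown here, no measured pair shows this exchange, so the size of the step cannot be read from the series. Given that compound 1 gives 4 nM, the expectation is a modest step of a 2.5-fold higher number from compound 1 to compound 4 (0.40 log units; beyond the scatter), most likely toward a somewhat higher number, though a result within the scatter would not be surprising. For compound 4 the estimated value in this assay is 10 nM, expected to fall between 3 nM and 40 nM.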

Compound 4, inhibition constant: 33 nM
Beside the measured number, compound 4's estimate is 3.3-fold (0.52 log units) below it; low and high end bracket the measured number.
By their numbers in this assay, from the lowest: compounds 1 and 2 (each within the scatter of the next); then compound 4; then compound 3.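

In this assay, among the compounds shown here, an 8.3-fold higher number from compound 1 to compound 4 (0.92 log units; beyond the scatter) provides the first comparison that isolates one change, and it shows that the saturated chain carbon bound to an aromatic carbon and a double-bonded chain carbon does not treat these two ring-bearing groups alike. The exchange alters two features together, replacing the non-aromatic ring of cyclohexyl with the aromatic ring of benzyl and introducing the methylene of benzyl, so this single pair shows sensitivity to the change without assigning it to either feature. No available measurement accounts for the size of this step.

Phenyl and cyclohexylmethyl at the same carbon would separate the contribution of the aromatic ring from that of the methylene, and the compounds shown do not settle which of the two matters. Also open, from the compounds shown here alone, is how an amine or a carboxylic acid at this carbon would read in this assay, and whether benzyl in place of cyclohexyl would give a step of similar size on a core with a different second aryl group.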